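A few compounds are considered here, and "the series" means these few. Any claim that something is new, unique, unknown or untested is made for them only; others in the source may bear on it.

Measured compounds:
compound 1 `O=C1C(=O)N(Cc2ccc(Br)cc2)c2ccccc21` gives 4600 nM
compound 2 `O=C1C(=O)N(Cc2ccc(Cl)nc2)c2ccc(OC(F)(F)F)cc21` gives 2400 nM

In a functional assay on CHO cells for positive allosteric modulation of muscarinic acetylcholine receptor M5 (Homo sapiens), read by FLIPR and calcium flux, with a stated time of 1 h (a higher number here means that more compound is needed for the effect, a lower number that less compound is needed), compound 2 gives 2400 nM. Its nearest neighbour among the measured compounds is compound 1, which gives 4600 nM; the gap between the two lies within the scatter of repeated measurements of this kind, so the numbers do not set one of them apart from the other. For the measured compounds named here, no pair of measured compounds differs in a single place, and no measured step is therefore available to guide the next move.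

Compound 3 `O=C1C(=O)N(Cc2ccc(-c3ccccc3)nc2)c2ccc(OC(F)(F)F)cc21` has not yet been measured. It differs from compound 2 in one respect: phenyl in place of chloro on an aromatic carbon. Going by the values given here, with no measured step to draw on, the expectation for compound 3 rests on this single change and on where compound 2 stands.

Compound 3 is expected to show a 1.6-fold lower number from compound 2 to compound 3 (0.20 log units; within the scatter), a step toward a lower number that may not clear the scatter. Compound 3 is estimated at 1500 nM, within a range from 500 nM to 6000 nM.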

Compound 3, half-maximal effective concentration: 3800 nM
The estimate for compound 3 lay 2.5-fold (0.40 log units) below the measured number; measured number inside the range.
By their numbers in this assay, from the lowest: compounds 2, 3 and 1 (each within the scatter of the next).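

In this assay, for the compounds shown here, the first measured change at this position, on an aromatic carbon next to the ring nitrogen, gives a 1.6-fold higher number from compound 2 to compound 3 (0.20 log units; within the scatter) when phenyl takes the place of chloro, so the numbers do not set compound 3 apart from compound 2. The position thus holds a group of 6 heavy atoms with a six-membered aromatic ring, where chloro has 1 heavy atom and no ring, and the compound still gives a measured number that this single step cannot distinguish from that of its chloro partner. No available measurement bears on what lies behind this result.

As far as these compounds go, it remains open whether a different group at this position, such as an amine, a carboxylic acid or a longer chain, would produce a step that clears the scatter in either direction. Going by these compounds alone, it is also open whether phenyl in place of chloro would read the same way on another core, since this conclusion rests on the single pair of compound 2 and compound 3.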